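The compounds below may be only part of what the source reports. "The series", "measured", "known", "first", "only" and "open" are said of these compounds alone.

Compound 1 `Cc1cc(Oc2ccc(/C=N/NC(=S)Nc3ccc(F)cc3)cc2)ccc1Cl` was measured in a physicochemical assay for lipophilicity, in phosphate buffer, measured as octanol-water partition, with a stated time of 24 h (a higher number here means a more lipophilic compound, a lower number a more polar compound), where compound 1 gives 6.07. Compound 2 `S=C(N/N=C/c1ccc(Oc2ccc3ccccc3c2)cc1)Nc1ccccc1`, a related compound with a different aromatic group on the oxygen, gives 6.07 in this assay, so compound 1 stands level with compound 2 at the digits shown, and the two values lie within the scatter of each other; no order between them can be read from this.

The step to compound 3 `Fc1ccc(NC(=S)N/N=C/c2ccc(Oc3ccc(F)cc3)cc2)cc1` changes one part of compound 1: 4-fluorophenyl in place of 4-chloro-3-methylphenyl on an oxygen on an aromatic ring. Within the data shown here, no measured pair in the data shows this kind of change, so the size of the step in this assay has to be estimated from the structures alone. A move toward a lower number is expected, with the expected step from compound 1 to compound 3 amounting to a number 0.97 log units lower from compound 1 to compound 3 (beyond the scatter). In this assay compound 3 is thus expected to give about 5.1, with a likely range from 4.6 to 5.7.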

Compound 3, partition coefficient: 5.19
The estimate for compound 3 lay 0.09 log units below the measured number, within the range that was stated.
By their numbers in this assay, from the lowest: compound 3; then compounds 1 and 2 (each within the scatter of the next).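

In this assay there is a number 0.88 log units lower from compound 1 to compound 3 (beyond the scatter) when 4-fluorophenyl takes the place of 4-chloro-3-methylphenyl on an oxygen on an aromatic ring. Among these compounds, the earlier pair offered no step that could be read, so this is the first sign that the group at this position can shift the read-out beyond the scatter while the rest of the molecule stays the same. The change removes the chlorine and the methyl and adds a fluorine all at once, so the step cannot be divided among them, and nothing measured here explains it.

The compounds shown leave open how much of the step belongs to the chlorine and how much to the methyl, which a plain phenyl group at the same place would begin to separate. They also leave open how this position responds to a group of a different kind, such as an amine or a carboxylic acid on that ring.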